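The compounds below may be only part of what the source reports. "The series", "measured", "known", "first", "only" and "open" are said of these compounds alone.

Series notes. Compound 2 `O=C(Nc1cccc(-c2ccc(O)cc2)c1)c1ccccc1` carries a hydrogen on the amide nitrogen. In an assay for binding affinity to 17-beta-hydroxysteroid dehydrogenase type 2 (Homo sapiens), with a stated time of 20 min, tested at 1 uM (on this read-out higher numbers stand for more inhibition at the one concentration tested (going by the name of the read-out) and lower numbers for less inhibition), compound 2 gives < 10%, which is a limit of the assay and not a number. Compound 1 `CN(C(=O)c1ccccc1)c1cccc(-c2ccc(CO)cc2)c1` likewise sits at a limit: in this assay compound 1 gives < 10%. Both values shown rest at the limit of < 10% in this assay, at which 2 of the 2 values shown sit, so compound 2 stands at the floor of what this assay reports, with nothing measured that rises above it. Compound 3 `CN(C(=O)c1ccccc1)c1cccc(-c2ccc(O)cc2)c1` is the next member: methyl in place of hydrogen on an amide-type nitrogen. Within the data shown here, with no measured step to go on, the expected change in this assay is none beyond the scatter, a step that the limit leaves unreadable from compound 2 to compound 3. Compound 3 is therefore expected to give 5%, within 0% to 15%.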

Compound 3, a percentage reported as inhibition, at one concentration (the size of the read-out at that concentration, not a potency): 46%
Compound 3: middle estimate off by 41 percentage points, on the low side; measured number above the stated range.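

In this assay, among these compounds, methyl in place of hydrogen on the amide-type nitrogen gives a number at least 36 percentage points higher from compound 2 to compound 3 (beyond the scatter), the only reading that rises off the floor. With that methyl kept, hydroxy in place of hydroxymethyl on an aromatic carbon gives a number at least 36 percentage points higher from compound 1 to compound 3 (beyond the scatter), so the read-out responds to both places. Both steps start from a limit and stand as bounds, not exact sizes: the limit of < 10% in this assay, at which 2 of the 3 values shown sit.

Going by these compounds, whether a longer chain such as ethyl can replace the methyl on the nitrogen remains open. So does whether an amine or a carboxylic acid can stand in place of the hydroxy.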